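Moving the pyridine attachment: what stability to expect

This account rests on a few compounds, and the source may have more. Where it says the series, first, only, none or still open, it means among the compounds named here.

Compound 1 `COc1cccc(S(=O)(=O)/C=C/c2ccccn2)c1` gives 74%
Compound 2 `COc1cccc(S(=O)(=O)/C=C/c2cccnc2)c1` gives 75%
Compound 3 `COc1cccc(S(=O)(=O)/C=C/c2cccnc2Cl)c1` gives 29%

Among the measured compounds shown here, in an ADME assay on microsomes from liver (Homo sapiens) for metabolic stability, read by LC-MS, using NADPH, with stated times of 5 min and 30 min, tested at 1 uM (a higher number here means that more of the compound is left, a lower number that less of the compound is left), compound 2, at 75%, stands level with compound 1 and well clear of compound 3, the one clearly lower value of the three.

Compound 4 `COc1cccc(S(=O)(=O)/C=C/c2ccncc2)c1` has the same atoms as compound 2, joined differently: pyridin-4-yl in place of pyridin-3-yl on a double-bonded chain carbon bound to a double-bonded chain carbon. Put simply, pyridin-4-yl sits in place of pyridin-3-yl on a double-bonded chain carbon bound to a double-bonded chain carbon.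

The closest measured change is a number 1 percentage points higher from compound 1 to compound 2 (within the scatter), a swap of the same kind at the same place. The other measured change is large, a number 46 percentage points lower from compound 2 to compound 3 (beyond the scatter), but it adds chloro in place of hydrogen on an aromatic carbon, and compound 4 gains no new atom. It therefore says little about this swap. For the measured compounds named here, only one measured step of the same kind exists, so the expectation rests on thin evidence, and the range has to stay wide.

The expected change in this assay is no step beyond the scatter, with an estimated a number 3 percentage points lower from compound 2 to compound 4 (within the scatter) as the working figure. Compound 4 is expected at 72% (estimated range 58% to 85%).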

Compound 4, percent of the compound remaining: 72%
The estimate for compound 4 equals the measured number at the digits printed; the range from low to high includes it.
By their numbers in this assay, from the lowest: compound 3; then compounds 4, 1 and 2 (each within the scatter of the next).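

With pyridin-4-yl in place, all three attachment forms of the pyridine on this double-bonded chain carbon have now been compared in this assay, and the new compound adds no separation: the swap gives a number 3 percentage points lower from compound 2 to compound 4 (within the scatter), and the comparison with the remaining form gives a number 2 percentage points lower from compound 1 to compound 4 (within the scatter). Among compounds 1, 2 and 4, then, which ring atom carries the chain makes no difference that this measurement can resolve, and the one step beyond the scatter remains the addition of chloro, a number 46 percentage points lower from compound 2 to compound 3 (beyond the scatter), so within this small set, adding an atom to the pyridine has mattered far more than moving the attachment point. The data offer no measured property that would explain why the three attachment forms read alike.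

On these data alone, whether this tolerance extends beyond pyridines stays open, since a plain phenyl ring, or a pyridine carrying an amine or a methoxy group, could read quite differently at this place. It is also unknown whether chloro on pyridin-4-yl or pyridin-2-yl would bring a step as large as the one seen on pyridin-3-yl.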